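The compounds below may be only part of what the source reports. "The series", "measured", "known", "first", "only" and "open" are said of these compounds alone.

Among the compounds with values here, in a functional assay on K562 cells (Homo sapiens) for inhibition, read by trypan blue exclusion, with a stated time of 72 h (on this read-out lower numbers stand for stronger inhibition and higher numbers for weaker inhibition), compound 1 (`COC(=O)Cn1c(=O)c(S(=O)(=O)c2ccc(F)cc2F)cc2cnc(Nc3ccc4[nH]ccc4c3)nc21`) gives 5000 nM, the higher of the two numbers measured so far. Compound 2 (`Cn1c(=O)c(S(=O)(=O)c2ccc(Cl)cc2Cl)cc2cnc(Nc3ccc4[nH]ccc4c3)nc21`) gives 1000 nM, and the gap between the two lies beyond the usual scatter. The next compound to be tested, compound 3 (`O=c1[nH]c2nc(Nc3ccc4[nH]ccc4c3)ncc2cc1S(=O)(=O)c1ccc(F)cc1F`), differs from compound 1 in one place, an aromatic nitrogen, where hydrogen stands in place of (methoxycarbonyl)methyl: hydrogen in place of (methoxycarbonyl)methyl on an aromatic nitrogen. Within the data shown here, no measured pair shows this change, so the data give no direct guide to its size, and any expectation is a weak one. Among the measured compounds shown here, the only lower number available is that of compound 2 at 1000 nM, so a modest move toward a lower number is tentatively expected. The estimated change, which may not clear the scatter, is a 2.0-fold lower number from compound 1 to compound 3 (0.30 log units; within the scatter). Compound 3 is estimated at 2500 nM, with an expected range from 600 nM to 10000 nM.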

Compound 3, half-maximal inhibitory concentration: 15000 nM
For compound 3 the middle estimate is 6.0-fold (0.78 log units) below the measured one, and the stated range ends below it.
By their numbers in this assay, from the lowest: compound 2; then compound 1; then compound 3.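

In this assay the loss of the (methoxycarbonyl)methyl group from the aromatic nitrogen, with hydrogen entering in its place, brings a 3.0-fold higher number from compound 1 to compound 3 (0.48 log units; beyond the scatter) and so weakens inhibition. This single pair shows that the group on this nitrogen matters in this assay, and that, with the (2,4-difluorophenyl)sulfonyl group held constant, the hydrogen compound is the weaker of the two. Nothing available gives a reason for this step.

The pair cannot tell whether the ester itself matters or whether the chain's mere presence on the nitrogen is enough. A carboxylic acid in place of the methyl ester, or a longer chain ending in an amine, would separate these two readings.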